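The compounds below may be only part of what the source reports. "The series", "measured", "known", "first", "only" and "open" are said of these compounds alone.

Compound 1, with the structure `O=c1[nH]/c(=N\OCCOc2ccccc2)ccn1[C@@H]1O[C@H](COP(=O)(O)OP(=O)(O)OP(=O)(O)O)[C@@H](O)[C@H]1O`, is the starting point. Going by the values given here, in a functional assay on 1321-N1 cells for agonist activity at P2Y purinoceptor 4 (Homo sapiens), read by scintillation counting and inositol phosphate accumulation (on this read-out lower numbers stand for an effect already at smaller amounts and higher numbers for an effect only at larger amounts of compound), compound 1 gives 430 nM, which is the highest of the three numbers measured so far; the two other compounds both sit at smaller amounts. Compound 2, with the structure `O=c1[nH]/c(=N\OCCCc2ccc(F)cc2)ccn1[C@@H]1O[C@H](COP(=O)(O)OP(=O)(O)OP(=O)(O)O)[C@@H](O)[C@H]1O`, gives 105 nM in this assay, and compound 3, with the structure `O=c1[nH]/c(=N\OCCCc2ccc(Br)cc2)ccn1[C@@H]1O[C@H](COP(=O)(O)OP(=O)(O)OP(=O)(O)O)[C@@H](O)[C@H]1O`, gives 141 nM. The step from compound 1 to compound 2 was a 4.1-fold lower number from compound 1 to compound 2 (0.61 log units; beyond the scatter), and the step from compound 1 to compound 3 was a 3.0-fold lower number from compound 1 to compound 3 (0.48 log units; beyond the scatter). Between the two substituted analogues the step was a 1.3-fold higher number from compound 2 to compound 3 (0.13 log units; within the scatter), so the two halogens cannot be told apart on these numbers.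

Compound 4, with the structure `O=c1[nH]/c(=N\OCCCc2ccc([N+](=O)[O-])cc2)ccn1[C@@H]1O[C@H](COP(=O)(O)OP(=O)(O)OP(=O)(O)O)[C@@H](O)[C@H]1O`, is the next member of this small set. It differs from compound 1 by 4-nitrobenzyl in place of phenoxy on a saturated chain carbon, two bonds along the chain from an oxygen. The two steps that bear on it are those from compound 1 to compound 2 and from compound 1 to compound 3: both replaced the phenoxy group by a substituted benzyl group at the same place and both gave a modest lowering of the number beyond the scatter. A step of similar size and direction, a 3.3-fold lower number from compound 1 to compound 4 (0.52 log units; beyond the scatter), is therefore expected. For compound 4 the estimate in this assay is 130 nM, with a range from 55 nM to 320 nM.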

Compound 4, half-maximal effective concentration: 84 nM
Compound 4: the middle estimate sits 1.5-fold (0.19 log units) above what was measured; the measured number falls inside the stated range.
By their numbers in this assay, from the lowest: compounds 4, 2 and 3 (each within the scatter of the next); then compound 1.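

In this assay a third kind of benzyl group follows the earlier two: a 5.1-fold lower number from compound 1 to compound 4 (0.71 log units; beyond the scatter) shows that 4-nitrobenzyl in place of phenoxy also lowers the number beyond the scatter, so the result is not confined to the halogen-bearing rings. The choice of ring substituent, however, cannot be read on these numbers, since a 1.7-fold lower number from compound 3 to compound 4 (0.22 log units; within the scatter) and a 1.3-fold lower number from compound 2 to compound 4 (0.10 log units; within the scatter) leave nitro indistinguishable from bromo and fluoro even though it brings different atoms. Nothing measured here explains either finding.

Going from 2-phenoxyethyl to a 3-(4-nitrophenyl)propyl chain removes the chain oxygen and adds a ring substituent in one move, so these compounds cannot separate the two changes; a plain benzyl group or a 4-nitrophenoxy group in the same place would begin to do so. Also open, on these data alone, is how far this tolerance extends, for example whether an amine or a carboxylic acid in place of the nitro group, or a longer chain, would give a similar number.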